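This account rests on a few compounds, and the source may have more. Where it says the series, first, only, none or still open, it means among the compounds named here.

Compound 3 `CCCCCCc1ccc(NC(=O)N[C@@H](C)c2ccccc2)cc1` gives 100% in an ADME assay on the whole organism with Oryza sativa as the target, tested at 1 uM (a lower number here means a stronger effect, a higher number a weaker effect of the compound at the concentration tested), the highest of the three numbers; compound 1 `Cc1ccc(NC(=O)N[C@@H](C)c2ccccc2)cc1` gives 99%, within the scatter of it, and compound 2 `C[C@H](NC(=O)Nc1ccc(C(C)(C)C)cc1)c1ccccc1` gives 88%, beyond the scatter below it. Compound 4 `C[C@H](NC(=O)Nc1ccc(C(F)(F)F)cc1)c1ccccc1` differs from compound 3 in one place: trifluoromethyl in place of hexyl on an aromatic carbon. Two measured steps exchange the same aromatic substituent: a number 11 percentage points lower from compound 1 to compound 2 (beyond the scatter), and a number 12 percentage points higher from compound 2 to compound 3 (beyond the scatter). Among the measured compounds shown here, both are modest, and no measured step exchanges hexyl for trifluoromethyl, so the direction is uncertain. A modest shift in this assay is therefore expected, more likely downward than upward, though a result within the scatter is quite possible. For compound 4 the estimate is 92%, with a range of 80% to 100%, the expected step being a number 8 percentage points lower from compound 3 to compound 4 (within the scatter).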

Compound 4, a percentage reported as activity, at one concentration (the size of the read-out at that concentration, not a potency): 94%
The estimate for compound 4 lay 2 percentage points below the measured number; the range from low to high includes it.
By their numbers in this assay, from the lowest: compounds 2, 4, 1 and 3 (each within the scatter of the next, the first and the last beyond it).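

In this assay, trifluoromethyl on the aromatic carbon reads within the scatter of all three earlier substituents: a number 6 percentage points lower from compound 3 to compound 4 (within the scatter) and a number 6 percentage points higher from compound 2 to compound 4 (within the scatter) and a number 5 percentage points lower from compound 1 to compound 4 (within the scatter) in turn. Compound 2 and compound 3 stay beyond the scatter of each other, yet compound 4 joins neither end, so the four substituents at this position form no clear trend. Nothing available explains these numbers. Still open, as far as these compounds go, is how an amine or a carboxylic acid on this aromatic carbon would read, and whether any group here gives a step larger than modest.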